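The compounds below may be only part of what the source reports. "The series", "measured", "known", "first", "only" and "open" are said of these compounds alone.

Notes on the series in an ADME assay on BJ cells (Homo sapiens) for cytotoxicity, read by CellTiter-Glo and resazurin assay, with a stated time of 72 h; a lower number here means that less compound is needed, a higher number that more compound is needed for the effect.

Among the measured compounds shown here, compound 1 `COc1cc(F)cc(-c2ccc(C(=O)N(Cc3cccc(OCCCCCC(=O)O)c3)C(C)C)cc2)c1` is the first member. In this assay compound 1 is reported only as a limit, > 26000 nM. Compound 2 `CCOC(=O)CCCCCOc1cccc(CN(C(=O)c2ccc(-c3cccnc3)cc2)C(C)C)c1` is the second member. In this assay compound 2 likewise stands only at a limit, > 26000 nM. Both measured values therefore sit at the limit of > 26000 nM in this assay, at which 2 of the 2 values shown sit, so no step within the measured set can be read, and on the numbers shown nothing separates compound 1 from compound 2; where compound 2 stands is simply at that limit.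

Compound 3 `CCOC(=O)CCCCCOc1cccc(CN(C(=O)c2ccc(-c3cc(OC)ccc3F)cc2)C(C)C)c1` is not yet measured. Compared with compound 2 the change is 2-fluoro-5-methoxyphenyl in place of pyridin-3-yl on an aromatic carbon. With both measured compounds at the limit, the size of the step cannot be drawn from any measured pair. The step expected in this assay is a step that the limit leaves unreadable from compound 2 to compound 3, that is none beyond the scatter. Compound 3 is accordingly expected to give 30000 nM in this assay, with a range of 12000 nM to 80000 nM, and most likely to be reported again only as a limit.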

Compound 3, half-maximal effective concentration: > 26000 nM
Compound 3 ended at the assay's limit (the forecaster's own chance of this, stated with the estimate: 85%); the middle value does not contradict the limit.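

Among the compounds shown here, no step from compound 2 to compound 3 can be read in this assay, since each is reported only as a limit: the limit of > 26000 nM in this assay, at which 3 of the 3 values shown sit.

The compounds shown leave open what concentration, if any, gives a half-maximal effect in this assay, and so how 2-fluoro-5-methoxyphenyl and pyridin-3-yl compare there.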